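One More Carbon on a Long Chain

A few compounds are considered here, and "the series" means these few. Any claim that something is new, unique, unknown or untested is made for them only; others in the source may bear on it.

Among the three measured compounds, compound 3 `CCCCCCCCCc1ccc(NC(=O)Nc2c(C(C)C)cccc2C(C)C)cc1` stands lowest in an assay on isolated protein for inhibition of acyl-CoA:cholesterol acyltransferase (Oryctolagus cuniculus) (on this read-out higher numbers stand for weaker inhibition and lower numbers for stronger inhibition), at 9 nM. In this assay compound 1 `CCCCCCc1ccc(NC(=O)Nc2c(C(C)C)cccc2C(C)C)cc1` gives 26 nM, and compound 2 `CC(C)c1cccc(C(C)C)c1NC(=O)Nc1ccc(C(C)(C)C)cc1` gives 168 nM. The step of a 2.9-fold lower number from compound 1 to compound 3 (0.46 log units; beyond the scatter) shows that making the chain on the aromatic carbon longer brought the number down, and the step of a 19-fold lower number from compound 2 to compound 3 (1.27 log units; beyond the scatter) shows a large drop when a branched group gave way to a long chain. The step of a 6.5-fold higher number from compound 1 to compound 2 (0.81 log units; beyond the scatter) runs the other way.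

Compound 4 `CCCCCCCCCCc1ccc(NC(=O)Nc2c(C(C)C)cccc2C(C)C)cc1` has not yet been measured. It differs from compound 3 in one place: methyl in place of hydrogen on a saturated chain carbon, nine bonds along the chain from an aromatic carbon. The step that bears most directly on this change is a 2.9-fold lower number from compound 1 to compound 3 (0.46 log units; beyond the scatter), since it also lengthened the same chain; the step of a 19-fold lower number from compound 2 to compound 3 (1.27 log units; beyond the scatter) points in the same direction but mixes in a change of branching. Both gave lower numbers. A single added carbon is a smaller change than either, so only a small further lowering, or no change beyond the scatter, is expected. Compound 4 is therefore estimated at 7 nM in this assay, with a range from 3 nM to 16 nM. The expected step of a 1.3-fold lower number from compound 3 to compound 4 (0.11 log units; within the scatter) is thus modest at most.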

Compound 4, half-maximal inhibitory concentration: 13 nM
The estimate for compound 4 lay 1.9-fold (0.27 log units) below the measured number; the range from low to high includes it.
By their numbers in this assay, from the lowest: compounds 3, 4 and 1 (each within the scatter of the next, the first and the last beyond it); then compound 2.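

On this assay the added methyl at the chain end, nine bonds along the chain from an aromatic carbon, gives a 1.4-fold higher number from compound 3 to compound 4 (0.16 log units; within the scatter) and so no readable change: going from nonyl to decyl does not clearly carry on the lowering that came with going from hexyl to nonyl. Decyl also cannot be told apart from hexyl, as a 2.0-fold lower number from compound 1 to compound 4 (0.30 log units; within the scatter) shows, even though nonyl could be told apart from hexyl with a 2.9-fold lower number from compound 1 to compound 3 (0.46 log units; beyond the scatter) and the two long chains themselves sit within the scatter of each other. What stays firm is the gap to the branched group, with a 13-fold lower number from compound 2 to compound 4 (1.11 log units; beyond the scatter) when decyl takes the place of tert-butyl, so the long straight chain keeps its clear distance from compound 2.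

Going by these compounds, whether a longer chain such as dodecyl would hold the number level or raise it stays open, as does what a carboxylic acid at the end of the chain would do. Nothing shown here offers an explanation for this flat stretch between nonyl and decyl.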